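Swapping the amide-nitrogen ring on a shared core

The source may report more compounds than this note shows. Statements on the series, on what has been measured and on what is new or still open speak of the compounds shown alone.

Measured compounds:
Compound 1, `O=C(COc1ccc(/C=C2\SC(=O)NC2=O)cc1)Nc1nc2ccccc2s1`: in a functional assay on PC-3 cells (Homo sapiens) for cytotoxicity, read by sulforhodamine B assay, with a stated time of 48 h (a lower number here means a stronger inhibitor of growth, a higher number a weaker inhibitor of growth), compound 1 gives < 100000 nM, which is a limit of the assay, not a number.
Compound 2, `O=C(COc1ccc(/C=C2\SC(=O)NC2=O)cc1)Nc1ncc([N+](=O)[O-])s1`: in this assay compound 2 gives < 100000 nM, again a limit.
Compound 3, `O=C(COc1ccc(/C=C2\SC(=O)NC2=O)cc1)Nc1ccccn1`: in this assay compound 3 gives < 100000 nM, also a limit.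

Compound 3 therefore stands only at a limit, and the two other values shown sit at the same limit (the limit of < 100000 nM in this assay, at which 3 of the 3 values shown sit). The steps among the measured compounds, a step that the two limits leave unreadable from compound 1 to compound 2, a step that the two limits leave unreadable from compound 1 to compound 3 and a step that the two limits leave unreadable from compound 2 to compound 3, cannot be read in size, since both ends of each are limits. Compound 4, `Cc1cc(NC(=O)COc2ccc(/C=C3\SC(=O)NC3=O)cc2)no1`, differs from compound 3 only at the amide-type nitrogen: 5-methyl-1,2-oxazol-3-yl in place of pyridin-2-yl on an amide-type nitrogen. For the measured compounds named here, none of the measured steps gives a readable size for a change at this position, so no direction can be taken from them. The expectation for compound 4 is simply that it behaves like the three measured compounds, which is the expected step that the limit leaves unreadable from compound 3 to compound 4. Compound 4 is therefore expected at about 40000 nM, within a range of 5000 nM to 100000 nM, with a fair chance that only a limit is reported again.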

Compound 4, concentration for total growth inhibition: < 100000 nM
Compound 4: only a limit was reported (the forecaster's own chance of this, stated with the estimate: 65%); the middle value does not contradict the limit.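

For the compounds shown here, compound 4 also gives only a limit, so no step from compound 1, compound 2 or compound 3 to compound 4 can be read in size: the limit of < 100000 nM in this assay, at which 4 of the 4 values shown sit. The compounds shown leave open how strongly each inhibits growth in this assay, and whether changing the ring on the amide-type nitrogen alters that at all.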